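A few compounds are considered here, and "the series" means these few. Any claim that something is new, unique, unknown or untested is made for them only; others in the source may bear on it.

Working notes on the series. Compound 1 `CC(C)[C@H](NC(=O)COc1cccc2ccccc12)C(=O)N[C@@H](CC(=O)O)C(=O)COc1cc(F)ccc1F` gives 19700 nM in a functional assay with Homo sapiens as the target; a higher number here means a weaker inhibitor, a lower number a stronger inhibitor; compound 2 `CC(C)[C@H](NC(=O)COc1cccc2ccccc12)C(=O)N[C@@H](CC(=O)O)C(=O)COc1ccc(F)c(F)c1` gives 16200 nM. Going by the values given here, compound 2 stands at the lowest of the two numbers so far, with compound 1 as its only neighbour; the step of a 1.2-fold lower number from compound 1 to compound 2 (0.08 log units; within the scatter) lies within the scatter, so the two compounds cannot be ordered against each other.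

The next compound, compound 3 `CC(C)[C@H](NC(=O)COc1cccc2ccccc12)C(=O)N[C@@H](CC(=O)O)C(=O)COc1cccc(C(F)(F)F)c1F`, is unmeasured. It differs from compound 2 as follows: 2-fluoro-3-(trifluoromethyl)phenyl in place of 3,4-difluorophenyl on an oxygen on a saturated carbon. Among the compounds with values here, the one measured step that bears on this place, a 1.2-fold lower number from compound 1 to compound 2 (0.08 log units; within the scatter), exchanged one difluorophenyl pattern for another and did not move the number beyond the scatter. Within the data shown here, the change to compound 3 is larger in what it brings in, a trifluoromethyl group alongside the fluorine, but no measured pair shows what a trifluoromethyl group does at this position, so the only guide is that the previous swap at this place was flat.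

The expectation for compound 3 is therefore a step of a 1.2-fold lower number from compound 2 to compound 3 (0.06 log units; within the scatter) that stays close to compound 2, with a wide range; compound 3 is estimated at 14000 nM, between 4500 nM and 45000 nM.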

Compound 3, half-maximal inhibitory concentration: 18200 nM
Estimate against measurement, compound 3: 1.3-fold (0.11 log units) below; the measured number falls inside the stated range.
By their numbers in this assay, from the lowest: compounds 2, 3 and 1 (each within the scatter of the next).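

In this assay the 2-fluoro-3-(trifluoromethyl)phenyl group on the oxygen gives a 1.1-fold higher number from compound 2 to compound 3 (0.05 log units; within the scatter) and, set against the 2,5-difluorophenyl group, a 1.1-fold lower number from compound 1 to compound 3 (0.03 log units; within the scatter) so all three compounds remain unordered. The earlier step compared only two difluorophenyl patterns of 8 heavy atoms each, whereas this change brings in 11 heavy atoms, including 4 fluorine atoms, and still does not separate the compounds at this place on an oxygen on a saturated carbon. Nothing available bears on why the numbers stay together here.

The compounds shown carry only fluorine and trifluoromethyl on the phenyl group, so it remains open whether an amine, a carboxylic acid or a longer chain at this place would give a step beyond the scatter. They also share the rest of the core of compound 1 unchanged, which leaves open whether the flat reading at this place would hold with any other group elsewhere in the structure.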